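The source may report more compounds than this note shows. Statements on the series, on what has been measured and on what is new or still open speak of the compounds shown alone.

Compound 2 `Cc1cc(N2CC[C@@H](C)[C@@H](N(C)c3ncnc4[nH]ccc34)C2)n2nc(SCCCc3ccccc3)nc2n1` is the starting point. In a functional assay on MGC-803 cells (Homo sapiens) for inhibition, read by MTT assay, with a stated time of 72 h (on this read-out higher numbers stand for weaker inhibition and lower numbers for stronger inhibition), compound 2 gives > 100000 nM, which is a limit of the assay and not a number. Within the data shown here, compound 1 `Cc1cc(N2CC[C@@H](C)[C@@H](N(C)c3ncnc4[nH]ccc34)C2)n2ncnc2n1` gives 4350 nM in this assay, and the measured step of an at least 22-fold higher number from compound 1 to compound 2 (1.36 log units; beyond the scatter) is the only change that bears here; compound 2 sits at the limit of > 100000 nM in this assay, at which 1 of the 2 values shown sits. Compound 3 `Cc1ccc(CSc2nc3nc(C)cc(N4CC[C@@H](C)[C@@H](N(C)c5ncnc6[nH]ccc56)C4)n3n2)cc1` differs by 4-methylphenyl in place of phenethyl on a saturated chain carbon bound to a sulfur, keeping a sulfur-linked group on the same aromatic carbon. The step of a number no higher from compound 2 to compound 3 (the limit leaves the size open) is therefore expected to be none beyond the scatter. For compound 3 the expected value is 100000 nM, in a range from 20000 nM to 300000 nM.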

Compound 3, half-maximal inhibitory concentration: 5860 nM
Compound 3: the middle estimate sits 17-fold (1.23 log units) above what was measured; the measured number lies below the stated range.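

A sulfur-linked group on this aromatic carbon need not cost activity in this assay: (4-methylbenzyl)sulfanyl in place of hydrogen gives a 1.3-fold higher number from compound 1 to compound 3 (0.13 log units; within the scatter). What hangs on the sulfur matters instead, as 4-methylbenzyl in place of 3-phenylpropyl gives an at least 17-fold lower number from compound 2 to compound 3 (1.23 log units; beyond the scatter). Compound 2 stands at a limit of the assay, not a number: the limit of > 100000 nM in this assay, at which 1 of the 3 values shown sits.

That step alters the chain and the ring together, and the compounds shown do not separate the two. Going by these compounds, whether an amine or a carboxylic acid on that ring would be tolerated also stays open.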